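This account rests on a few compounds, and the source may have more. Where it says the series, first, only, none or still open, it means among the compounds named here.

Working notes on the series, concerning the step from compound 1 to compound 4.

Among the compounds with values here, compound 1 `CCCCCCCCc1ccc(CCC(N)(CO)C(=O)O)cc1` is the only compound of the three carrying a carboxy group. In a functional assay on the whole organism (spleen, spleen) with Rattus norvegicus as the target (on this read-out lower numbers stand for an effect already at smaller amounts and higher numbers for an effect only at larger amounts of compound), compound 1 reaches only the limit of the assay, > 10 mg/kg, and so there is no number for it, just the bound itself, as recorded in the limit of > 10 mg/kg in this assay, at which 1 of the 3 values shown sits. The two compounds with a number are amino alcohols: compound 2 `CCCCCCCOc1ccc(CCC(N)(CC)CO)cc1` gives 0.059 mg/kg in this assay, and compound 3 `C=CCC(N)(CO)CCc1ccc(OCCCCCCC)cc1` gives 1.9 mg/kg. Within the data shown here, the one measured step, a 32-fold higher number from compound 2 to compound 3 (1.51 log units; beyond the scatter), concerns a different position from the one changed here and therefore does not bear directly on compound 4.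

Compound 4 `CCCCCCCCc1ccc(CCC(N)(CO)CCCO)cc1` differs from compound 1 by 3-hydroxypropyl in place of carboxy on a saturated chain carbon bound to an amine nitrogen and two saturated chain carbons. The change removes the carboxy group and leaves an amino alcohol with two hydroxyl-bearing chains on the core, which brings compound 4 closer in type to compound 2 and compound 3 than to compound 1. Since compound 1 stands only at a limit, the step can only be read as an expectation that compound 4 moves into the measurable range, in the direction of the numbers shown for compound 2 and compound 3, that is an at least 20-fold lower number from compound 1 to compound 4 (1.30 log units; beyond the scatter). Among the measured compounds shown here, compound 4 is therefore estimated at 0.5 mg/kg, with a range from 0.05 mg/kg to 5 mg/kg, the width reflecting that no measured step covers this change.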

Compound 4, dose for 50% inhibition: 0.085 mg/kg
Compound 4: middle estimate off by 5.9-fold (0.77 log units), on the high side; the range from low to high includes it.
By their numbers in this assay, from the lowest: compounds 2 and 4 (each within the scatter of the next); then compound 3. At a limit, above all of these: compound 1.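

Setting 3-hydroxypropyl in place of carboxy on a saturated chain carbon bound to an amine nitrogen and two saturated chain carbons gives an at least 110-fold lower number from compound 1 to compound 4 (2.07 log units; beyond the scatter) in this assay, the only step shown at this place. Compound 1 stands only at a limit, so the size of this step is a bound and not an exact figure: the limit of > 10 mg/kg in this assay, at which 1 of the 4 values shown sits.

Within the data shown here, the earlier step concerned a different change at a different place, so this pair gives the only reading of carboxy, and that reading rests on these two compounds alone.

From the compounds shown here alone, a single pair cannot separate the departure of carboxy from the arrival of 3-hydroxypropyl, and it remains open how much of the step belongs to each. Also open, going by these compounds, is how this carbon would read with a primary carboxamide or a methyl ester in place of carboxy, or with a 2-hydroxyethyl or 4-hydroxybutyl chain in place of 3-hydroxypropyl.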